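A few compounds are considered here, and "the series" means these few. Any claim that something is new, unique, unknown or untested is made for them only; others in the source may bear on it.

Measured so far:

Compound 1, `Cc1cc([C@@H]2[C@@H](CO)CCN2C)on1`: in an assay on cell membranes for displacement of a labelled ligand from Neuronal acetylcholine receptor; alpha4/beta2 (Rattus norvegicus) (on this read-out higher numbers stand for weaker inhibition and lower numbers for stronger inhibition), compound 1 gives > 10000 nM, which is a limit of the assay and not a number.

Compound 2, `Cc1cc([C@@H]2[C@@H](COC(=S)Oc3ccccc3)CCN2C)on1`: in this assay compound 2 gives 840 nM.

Compound 1 therefore stands at the weak end of what is shown: only a limit is known for it (the limit of > 10000 nM in this assay, at which 1 of the 2 values shown sits), so its true value could be anywhere beyond that point. Going by the values given here, compound 2 is the only compound with an actual number in this assay.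

The unmeasured compound 3, `Cc1cc([C@@H]2[C@@H](C)CCN2C)on1`, differs from compound 1 by a single change: hydrogen in place of hydroxy on a saturated chain carbon bound to a saturated ring carbon. Among the compounds with values here, no pair of measured compounds differing in one place is available, so the size of this step has to be judged without a direct precedent. Because compound 1 sits at the limit of > 10000 nM in this assay, at which 1 of the 2 values shown sits, any worsening would stay hidden behind the same limit, and only an improvement could show up as a number. A small change of this kind is expected to give, at most, a modest gain in this assay, quite possibly nothing beyond the usual scatter, with a fair chance that the assay again reports only a limit. Compound 3 is therefore estimated at 8000 nM, with a likely range from 1500 nM to 30000 nM. The expected step of an at least 1.2-fold lower number from compound 1 to compound 3 (0.09 log units; that floor lies within the scatter) is what this estimate implies.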

Compound 3, inhibition constant: > 10000 nM
Compound 3 ended at the assay's limit; the forecaster's own chance of this, stated with the estimate: 50%; at least 1.2-fold (0.09 log units) between middle value and limit.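

Compound 1 and compound 3 both end at a limit of the assay and not at a number, so the step between them cannot be read: the limit of > 10000 nM in this assay, at which 2 of the 3 values shown sit.

The compounds shown leave open how far beyond that limit each of the two lies, and whether changing hydroxymethyl to methyl makes any difference in this assay.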